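Chlorine on the benzyl ring of compound 1

This account rests on a few compounds, and the source may have more. Where it says the series, first, only, none or still open, it means among the compounds named here.

Compound 1 `CCC(COc1cccc(C(F)(F)F)c1)OC(=O)NCc1ccccc1` is the reference point of this small set. In an assay for inhibition of zeta-carotene desaturase, chloroplastic/chromoplastic (Capsicum annuum), using a Dixon plot, with a stated time of 8 h (on this read-out lower numbers stand for stronger inhibition and higher numbers for weaker inhibition), compound 1 shows only a limit of the assay, > 100000 nM. Compound 2 `CCC(COc1cccc(Cl)c1)OC(=O)NCc1ccccc1` also sits at a limit, > 100000 nM. Compound 3 `CCC(COc1cccc(C(=O)O)c1)OC(=O)NCc1ccccc1` likewise gives a limit, > 100000 nM. All three values sit at the limit of > 100000 nM in this assay, at which 3 of the 3 values shown sit, so the steps a step that the two limits leave unreadable from compound 1 to compound 2, a step that the two limits leave unreadable from compound 1 to compound 3 and a step that the two limits leave unreadable from compound 2 to compound 3 remain unreadable. Compound 4 `CCC(COc1cccc(C(F)(F)F)c1)OC(=O)NCc1ccccc1Cl` differs from compound 1 by chloro in place of hydrogen on an aromatic carbon. The measured steps all alter the substituent of the aryloxy ring, not the benzyl ring, so none bears directly on this change. With no readable step anywhere in the set, compound 4 is expected to remain at the limit, estimated near 100000 nM with a range from 30000 nM to 300000 nM. The step of a number no higher from compound 1 to compound 4 (the limit leaves the size open) is thus expected to stay within scatter.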

Compound 4, half-maximal inhibitory concentration: > 100000 nM
Compound 4: a limit, no number; the forecaster's own chance of this, stated with the estimate: 85%; the middle value sits exactly at the limit.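

No step between compound 1 and compound 4 can be read in this assay, and the steps among all four compounds stay unreadable: the limit of > 100000 nM in this assay, at which 4 of the 4 values shown sit.

The compounds shown leave open whether any of these substituent changes alters inhibition at all.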